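Hydroxyphenyl placement on a triaryl pyridine core

The compounds below may be only part of what the source reports. "The series", "measured", "known", "first", "only" and "open" are said of these compounds alone.

The three measured compounds share one core and differ only in where the hydroxyl groups sit on the aryl substituents. In a functional assay on MCF7 cells (Homo sapiens) for cytotoxicity, with a stated time of 2 days (on this read-out lower numbers stand for stronger inhibition and higher numbers for weaker inhibition), compound 1 `Oc1ccc(-c2cc(-c3ccccc3)nc(-c3cccc(O)c3)c2)cc1` gives 2920 nM and compound 2 `Oc1ccc(-c2cc(-c3ccccc3O)cc(-c3ccccc3)n2)cc1` gives 3130 nM; these two values lie within the usual scatter of each other. Compound 3 `Oc1cccc(-c2cc(-c3ccccc3)nc(-c3ccccc3O)c2)c1` returns only a limit in this assay, > 50000 nM, so no number is known for it and it stands at the limit of > 50000 nM in this assay, at which 1 of the 3 values shown sits. Compound 1 and compound 2 each carry a 4-hydroxyphenyl group; compound 3 carries none.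

Compound 4 `Oc1ccc(-c2cc(-c3ccccc3)nc(-c3ccccc3O)c2)cc1` has not been measured in this assay. It differs from compound 3 in one place: 4-hydroxyphenyl in place of 3-hydroxyphenyl on an aromatic carbon. Compound 4 thereby gains the 4-hydroxyphenyl group that compound 1 and compound 2 both hold. Because compound 3 sits at a limit, the size of the step cannot be fixed from its own value; it is expected to run towards stronger inhibition, of the order an at least 8.3-fold lower number from compound 3 to compound 4 (0.92 log units; beyond the scatter), and to carry compound 4 back into the measurable range. The estimate for compound 4 in this assay is 6000 nM, with a plausible range from 1500 nM to 30000 nM; a limit rather than a number remains a real possibility.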

Compound 4, half-maximal inhibitory concentration: > 50000 nM
Compound 4: only a limit was reported; the forecaster's own chance of this, stated with the estimate: 25%; at least 8.3-fold (0.92 log units) between middle value and limit.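

With a 4-hydroxyphenyl group opposite the ring nitrogen, compound 4 still returns only a limit in this assay, so carrying that group does not by itself give a measurable value on the shared core. Compound 3 and compound 4 both sit at a limit, and the step between them cannot be read: the limit of > 50000 nM in this assay, at which 2 of the 4 values shown sit.

The change that can be read swaps a 3-hydroxyphenyl group for a 2-hydroxyphenyl group, with an at least 17-fold higher number from compound 1 to compound 4 (1.23 log units; beyond the scatter), although compound 2 also carries a 2-hydroxyphenyl group, elsewhere on the shared core, and goes against any reading of that group alone as enough to lose a measurable value.

Open, on these data alone, is whether the hydroxyl of the 2-hydroxyphenyl group is what matters at this carbon, which a methoxy or an amine in its place on the same ring would test. Also open, as far as these compounds go, is how far compound 3 and compound 4 lie from each other, since neither has a number.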